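A few compounds are considered here, and "the series" means these few. Any claim that something is new, unique, unknown or untested is made for them only; others in the source may bear on it.

Compound 1, `c1ccc(COc2ccc3c(c2)OCCO3)cc1`: 168 nM
Compound 2, `c1ccc(CCCOc2ccc3c(c2)OCCO3)cc1`: 947 nM
Compound 3, `c1ccc(OCCOc2ccc3c(c2)OCCO3)cc1`: 109 nM

All three were measured in an assay on isolated protein for inhibition of Amine oxidase [flavin-containing] B (Homo sapiens), read by fluorescence and spectrophotometry; a higher number here means a weaker inhibitor, a lower number a stronger inhibitor. Compound 3 has the lowest of the three numbers; compound 1 sits close to it, within the scatter, while compound 2 stands well beyond the scatter with a much higher number. Compound 4, `Brc1ccc(OCCOc2ccc3c(c2)OCCO3)cc1`, has not yet been measured. It differs from compound 3 by bromo in place of hydrogen on an aromatic carbon. Among the compounds with values here, no measured pair shows what such a change does here, so the expectation rests on compound 3 alone. The expected step is a 1.8-fold lower number from compound 3 to compound 4 (0.26 log units; within the scatter), a small move toward a lower number that may not rise beyond the scatter. Compound 4 is therefore estimated at 60 nM in this assay, within 15 nM to 250 nM.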

Compound 4, half-maximal inhibitory concentration: 941 nM
Estimate against measurement, compound 4: 16-fold (1.20 log units) below; the whole stated range lies below it.
By their numbers in this assay, from the lowest: compounds 3 and 1 (each within the scatter of the next); then compounds 4 and 2 (each within the scatter of the next).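

In this assay the change from phenyl to 4-bromophenyl gives an 8.6-fold higher number from compound 3 to compound 4 (0.94 log units; beyond the scatter) and so carries a real cost, the first sign that this aromatic ring is sensitive to substitution. The earlier compounds shown here all keep this ring unsubstituted and differ only in the chain, so they could not show this. Nothing available accounts for the step.

On these data alone, whether fluoro, chloro or methoxy in the same place would bring a similar loss remains open. So does whether bromo would have the same effect on compound 1 .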